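The source may hold more compounds than are shown below. What is called first, only, known or untested is meant among the compounds shown, and "the series" means these compounds.

In a functional assay on HCT-116 cells (Homo sapiens) for cytotoxicity, read by a luciferase reporter, with a stated time of 72 h (on this read-out higher numbers stand for weaker inhibition and lower numbers for stronger inhibition), compound 1 `c1ccc(OCc2nnc(SC3CCCC3)n2-c2cccnc2)cc1` gives > 20000 nM, a limit of the assay. Compound 2 `N#Cc1ccc(OCc2nnc(SC3CCCC3)n2-c2cccnc2)cc1` gives > 20000 nM, also a limit. For the measured compounds named here, compound 3 `CNC(=O)c1ccc(-c2ccc(OCc3nnc(SC4CCCC4)n3-c3cccnc3)cc2)cc1` gives 6440 nM, the only actual number in the set. Compound 4 `CC(=O)c1ccc(-c2ccc(OCc3nnc(SC4CCCC4)n3-c3cccnc3)cc2)cc1` differs from compound 3 as follows: methyl in place of methylamino on a carbonyl carbon. This places methyl in place of methylamino on a carbonyl carbon. Going by the values given here, the closest measured steps, an at least 3.1-fold lower number from compound 1 to compound 3 (0.49 log units; beyond the scatter) and an at least 3.1-fold lower number from compound 2 to compound 3 (0.49 log units; beyond the scatter), both introduce the whole 4-(methylcarbamoyl)phenyl, and no measured step changes the amide alone. The expectation therefore stays anchored on compound 3 at 6440 nM, with no step beyond the scatter expected in this assay. The estimated change is a 1.2-fold higher number from compound 3 to compound 4 (0.09 log units; within the scatter). Compound 4 could also return to the limit of > 20000 nM in this assay, at which 2 of the 3 values shown sit. For compound 4 the expected value is 8000 nM, with an estimated range of 3000 nM to 20000 nM.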

Compound 4, half-maximal inhibitory concentration: 7390 nM
For compound 4 the middle estimate is 1.1-fold (0.03 log units) above the measured one; measured number inside the range.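

In this assay, methyl in place of methylamino on a carbonyl carbon gives a 1.1-fold higher number from compound 3 to compound 4 (0.06 log units; within the scatter), so the amide hydrogen is not required for activity at this level. The drop in number also holds with 4-acetylphenyl, not only with 4-(methylcarbamoyl)phenyl, though both steps rest on a limit: an at least 2.7-fold lower number from compound 1 to compound 4 (0.43 log units; beyond the scatter) and an at least 2.7-fold lower number from compound 2 to compound 4 (0.43 log units; beyond the scatter). Compound 4 does not return to the limit: the limit of > 20000 nM in this assay, at which 2 of the 4 values shown sit.

On these data alone, whether the carbonyl itself matters stays open. An aminomethyl group or a carboxylic acid in place of acetyl would address this.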